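The compounds below may be only part of what the source reports. "The series", "measured", "known", "first", "only" and "open" are said of these compounds alone.

Measured in a physicochemical assay for lipophilicity; on this read-out higher numbers stand for higher lipophilicity and lower numbers for lower lipophilicity:
Compound 1 `COc1ccccc1C1=NC(c2ccccc2)CO1`: 3.76
Compound 2 `Fc1cccc(F)c1-c1ncco1`: 1.45
Compound 3 `Clc1cccc(C2=NC(c3ccccc3)CO2)c1Cl`: 4.28

Compound 1 stands in the middle of these three, lower than compound 3 and higher than compound 2, with both gaps beyond the scatter. Compound 4 `FC(F)(F)c1ccccc1C1=NC(c2ccccc2)CO1` has not yet been measured. It differs from compound 1 by trifluoromethyl in place of methoxy on an aromatic carbon. Among the compounds with values here, no measured pair shows this swap directly, so the expectation is only a rough one. With the core of compound 1 but no methoxy, compound 3 reads 4.28, which offers a nearby reference. In this assay, the expected step of a number 0.64 log units higher from compound 1 to compound 4 (beyond the scatter) is a rise beyond the scatter. Compound 4 is estimated at 4.4, with an expected range from 4 to 4.8.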

Compound 4, partition coefficient: 3.71
The estimate for compound 4 lay 0.69 log units above the measured number, outside the stated range (below it).
By their numbers in this assay, from the lowest: compound 2; then compounds 4 and 1 (each within the scatter of the next); then compound 3.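

On an aromatic carbon ortho to a large group, trifluoromethyl in place of methoxy gives a number 0.05 log units lower from compound 1 to compound 4 (within the scatter) in this assay and so leaves the read-out within the scatter. Within the data shown here, this is the first direct view of this swap, and it shows that these two groups cannot be told apart here, even though trifluoromethyl has more heavy atoms and no hydrogen-bond acceptor. No measurement at hand explains this match. On these data alone, whether an amine or a carboxylic acid at this position would also read like methoxy remains open, as does whether this match holds on a different core.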